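Cytotoxicity notes: hydroxy addition on the aryl ring

The source may hold more compounds than are shown below. What is called first, only, known or untested is meant among the compounds shown, and "the series" means these compounds.

Measured compounds in an ADME assay on MDCK cells (Canis lupus familiaris) for cytotoxicity; on this read-out lower numbers stand for higher toxicity in this test and higher numbers for lower toxicity in this test:
- compound 1 `CSc1nc2n(n1)C(c1ccc(O)cc1O)C([N+](=O)[O-])=NN2` gives 201000 nM
- compound 2 `O=[N+]([O-])C1=CNc2nc(-c3ccco3)nn2C1` gives 108000 nM
- compound 3 `O=[N+]([O-])C1=CNc2nc(-c3ccco3)nn2C1c1ccc(O)cc1O` gives 119000 nM

Compound 3 stands second highest of the three numbers, close to compound 2 and somewhat further from compound 1, with both gaps inside the scatter. Within the data shown here, the only single-point step so far, a 1.1-fold higher number from compound 2 to compound 3 (0.04 log units; within the scatter), comes from putting the 2,4-dihydroxyphenyl in place of hydrogen on a saturated ring carbon, and it did not move the number beyond the scatter. All three numbers sit in one band.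

Compound 4 `O=[N+]([O-])C1=CNc2nc(-c3ccco3)nn2C1c1c(O)cc(O)cc1O` is the next step from compound 3: hydroxy in place of hydrogen on an aromatic carbon. Among the measured compounds shown here, the one measured step that touches this ring, a 1.1-fold higher number from compound 2 to compound 3 (0.04 log units; within the scatter), is the nearest guide, and it was flat. For the measured compounds named here, there is no measured example of a third hydroxy group on that ring, so the expectation rests on the flat band alone. A step of about a 1.0-fold higher number from compound 3 to compound 4 (0.00 log units; within the scatter) is expected, within the scatter. Compound 4 is estimated at 120000 nM, in the range 60000 nM to 240000 nM.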

Compound 4, half-maximal cytotoxic concentration: 280000 nM
For compound 4 the middle estimate is 2.3-fold (0.37 log units) below the measured one; the measured number lies above the stated range.
By their numbers in this assay, from the lowest: compounds 2, 3, 1 and 4 (each within the scatter of the next, the first and the last beyond it).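

Among these compounds, the hydroxy group entering on the aromatic carbon, ortho to a large group and meta to two hydroxy groups, gives the first step in this assay that clears the scatter: a 2.4-fold higher number from compound 3 to compound 4 (0.37 log units; beyond the scatter). This aryl ring therefore does register on this read-out, whereas the earlier step, a 1.1-fold higher number from compound 2 to compound 3 (0.04 log units; within the scatter), stayed flat, and the shift runs towards lower toxicity in this test. No supporting measurement bears on why the third hydroxy group has this effect.

Open, as far as these compounds go, is whether the rise is specific to a hydroxy group at this place, as a methoxy group, a fluorine or an amine on the same aromatic carbon would show. Also open, from the compounds shown here alone, is whether the same change carries over to the core of compound 1, which has the methylthio group in place of the furan.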